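Swapping the aniline amino for a methoxy group

A few compounds are considered here, and "the series" means these few. Any claim that something is new, unique, unknown or untested is made for them only; others in the source may bear on it.

Measured compounds:
compound 1, `COc1cc(-c2cc(/C=C/C(=O)c3ccc(N)cc3)[nH]n2)cc(OC)c1OC`, -3%
compound 2, `COc1ccc(-c2cc(/C=C/C(=O)c3ccc(N)cc3)[nH]n2)cc1OC`, 2%
compound 3, `COc1ccc(-c2cc(/C=C/C(=O)c3cc(OC)c(OC)c(OC)c3)[nH]n2)cc1OC`, -7%

In a functional assay on NCI/ADR-RES cells (Homo sapiens) for cytotoxicity, read by sulforhodamine B assay, with a stated time of 48 h, tested at 100 uM (a lower number here means a stronger effect, a higher number a weaker effect of the compound at the concentration tested), compound 1 sits second highest of the three numbers; compound 3 lies a few points lower and compound 2 a few points higher, all within the scatter. Compound 4 is `COc1ccc(C(=O)/C=C/c2cc(-c3cc(OC)c(OC)c(OC)c3)n[nH]2)cc1`. It differs from compound 1 by methoxy in place of amino on an aromatic carbon. Among the compounds with values here, no measured step covers this change; the only one-place step, a number 5 percentage points higher from compound 1 to compound 2 (within the scatter), is within the scatter, and compound 3, which also lacks the amino group, shows a number close to that of compound 1. The expected step is therefore a number 1 percentage points higher from compound 1 to compound 4 (within the scatter), none beyond the scatter. Compound 4 is estimated at -2%, within -15% to 12%.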

Compound 4, a percentage reported as activity, at one concentration (the size of the read-out at that concentration, not a potency): -6%
Estimate against measurement, compound 4: 4 percentage points above; the measured number falls inside the stated range.
By their numbers in this assay, from the lowest: compounds 3, 4, 1 and 2 (each within the scatter of the next).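

In this assay, replacing 4-aminophenyl with 4-methoxyphenyl gives a number 3 percentage points lower from compound 1 to compound 4 (within the scatter), the first one-place step read at this position, para to a large group. At this concentration, methoxy therefore takes the place of amino without a step beyond the scatter. No measurement here offers an explanation for this result. The compounds shown leave open whether a carboxylic acid, a nitrile or a longer chain at this position would move the number beyond the scatter. They also leave open whether amino and methoxy would separate at lower concentrations.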